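This account rests on a few compounds, and the source may have more. Where it says the series, first, only, none or still open, it means among the compounds named here.

Measured compounds:
compound 1, `CC(C)OC(=O)OCOC(=O)C1=C(S[C@@H]2CN[C@H](C(=O)Nc3cccc(C(=O)O)c3)C2)[C@H](C)[C@@H]2[C@@H]([C@@H](C)O)C(=O)N12`: 0%
compound 2, `CCOC(=O)OCOC(=O)C1=C(S[C@@H]2CN[C@H](C(=O)Nc3cccc(C(=O)O)c3)C2)[C@H](C)[C@@H]2[C@@H]([C@@H](C)O)C(=O)N12`: 0%
compound 3, `C[C@@H](O)[C@H]1C(=O)N2C(C(=O)O)=C(S[C@@H]3CN[C@H](C(=O)Nc4cccc(C(=O)OCOC(=O)C(C)(C)C)c4)C3)[C@H](C)[C@H]12`: 0%

The study compares three measured compounds and one still to be measured in an ADME assay on a cell-free system (plasma, Rattus norvegicus) for metabolic stability, read by LC-MS, with a stated time of 60 min, at 37 degrees C, tested at 50 uM; on this read-out lower numbers stand for a less stable compound and higher numbers for a more stable compound. In this assay compound 1 gives 0%, compound 2 gives 0%, and compound 3 gives 0%. Every measured compound thus sits at the floor of the read-out, where the percent remaining cannot fall further.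

Compound 2 differs from compound 1 by hydrogen in place of methyl on a saturated chain carbon bound to an oxygen next to a carbonyl group and a saturated chain carbon, and that change gave no change at the digits printed from compound 1 to compound 2 (within the scatter). Compound 3 and compound 1 differ in more than one place; the difference between the two cores is not broken down here. Compound 3 stands level with compounds 1 and 2, nearest to compound 1 and furthest from compound 2, with no change beyond the scatter on either side.

Compound 4, `CC(C)C(=O)OCOC(=O)c1cccc(NC(=O)[C@@H]2C[C@H](SC3=C(C(=O)O)N4C(=O)[C@H]([C@@H](C)O)[C@H]4[C@H]3C)CN2)c1`, is not yet measured. It differs from compound 3 by hydrogen in place of methyl on a saturated chain carbon bound to a carbonyl carbon and two saturated chain carbons. Going by the values given here, this is the same kind of change as the one from compound 1 to compound 2, but not the same change: in the earlier pair the carbon carrying the methyl is bound to an oxygen next to a carbonyl group and a saturated chain carbon, whereas here it is bound to a carbonyl carbon and two saturated chain carbons. Because the earlier instance gave no change at the digits printed from compound 1 to compound 2 (within the scatter) and because compound 3 gives 0%, the step in this assay from compound 3 to compound 4 is expected to be no change at the digits printed from compound 3 to compound 4 (within the scatter). Compound 4 is accordingly estimated at 0% in this assay, with an expected range from 0% to 8%.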

Compound 4, percent of the compound remaining: 0%
Compound 4: the middle estimate sits on the measured number at the digits printed; the range from low to high includes it.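

In this assay compound 4 gives 0%, and the change of tert-butyl to isopropyl, hydrogen in place of methyl, gave no change at the digits printed from compound 3 to compound 4 (within the scatter). Set beside the earlier step, the replacement of methyl by hydrogen reads alike in both places: the same change on two cores in this assay, no change at the digits printed (within the scatter) from compound 1 to compound 2 and no change at the digits printed (within the scatter) from compound 3 to compound 4, 0 percentage points apart, within the scatter of two such steps. Going by these compounds alone, with all four compounds at the floor of the read-out, where the percent remaining cannot fall further, this shows only that neither step lifted a compound off that floor; it does not show that the change is without effect, or that a step of a given size would carry from one core to the other in a compound with a measurable amount remaining.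

The compounds shown leave open whether a longer chain or a cyclohexyl group in place of the isopropyl or tert-butyl, or an amide in place of the ester, would lift a compound off the floor of the read-out. They also leave open how the replacement of methyl by hydrogen would read on a compound that still remains after the stated time in this assay.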